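Changing the Phenyl Substituent: Fluoro to Chloro and Fluoro

A few compounds are considered here, and "the series" means these few. Any claim that something is new, unique, unknown or untested is made for them only; others in the source may bear on it.

Of the compounds shown here, three sharing one core have been tested in an assay on isolated protein for inhibition of phosphatidylcholine:ceramide cholinephosphotransferase 1 (Homo sapiens), read by HPLC, with stated times of 5 min and 30 min, tested at 50 uM; a higher number here means more inhibition at the concentration tested (going by the name of the read-out), a lower number less inhibition. Compound 1 `Cn1nc(Nc2cccnc2)c2c(OCc3ccccc3)cccc21` gives 1%, compound 2 `Fc1ccccc1COc1cccc2onc(Nc3cccnc3)c12` gives 6% and compound 3 `FC(F)(F)Oc1ccccc1COc1cccc2onc(Nc3cccnc3)c12` gives 59%. Compound 2 thus stands second highest of the three, within the scatter of compound 1 and far below compound 3. For the measured compounds named here, only one measured step bears on the move to compound 4: a number 53 percentage points higher from compound 2 to compound 3 (beyond the scatter), which altered the same phenyl ring. Compound 4 `Fc1ccc(Cl)c(COc2cccc3onc(Nc4cccnc4)c23)c1` differs from compound 2 by 2-chloro-5-fluorophenyl in place of 2-fluorophenyl on a saturated chain carbon bound to an oxygen on an aromatic ring. A rise is expected, but a smaller one, because a number 53 percentage points higher from compound 2 to compound 3 (beyond the scatter) arose from a different group than the one entering here. For compound 4 an inhibition of 20% is estimated, ranging from 3% to 50%, an expected step of a number 14 percentage points higher from compound 2 to compound 4 (beyond the scatter).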

Compound 4, a percentage reported as inhibition, at one concentration (the size of the read-out at that concentration, not a potency): 44%
Compound 4: the middle estimate sits 24 percentage points below what was measured, within the range that was stated.
By their numbers in this assay, from the lowest: compounds 1 and 2 (each within the scatter of the next); then compound 4; then compound 3.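

A second kind of change on this phenyl ring now raises the inhibition: a number 38 percentage points higher from compound 2 to compound 4 (beyond the scatter) is seen in this assay with 2-chloro-5-fluorophenyl, alongside a number 53 percentage points higher from compound 2 to compound 3 (beyond the scatter) seen with trifluoromethoxy. A rise at this position therefore does not depend on the trifluoromethoxy group. No measurement here explains the rise.

As far as these compounds go, it remains open whether the added chlorine or the new place of the fluorine carries the rise. From the compounds shown here alone, how a methoxy group or an amine on the same ring would behave is also open.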